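The source may report more compounds than this note shows. Statements on the series, on what has been measured and on what is new or still open speak of the compounds shown alone.

In a functional assay on HO8910 cells (Homo sapiens) for inhibition, read by MTT assay, with a stated time of 24 h, tested at 10 ug/mL (on this read-out higher numbers stand for more inhibition of growth at the one concentration tested and lower numbers for less inhibition of growth), compound 1 `O=C(CCCCC(S)CCS)NO` gives 26.2% and compound 2 `O=C(CCCCC1CCSS1)Nc1ccc(Cl)cn1` gives 27.5%, two values within the usual scatter of each other. On these data alone, compound 3 `O=C(CCCCC(S)CCS)Nc1ccccn1` stands apart from both: it is reported as "not active" (no number reported), with no number, so its exact place on this scale is unknown. Compound 4 `O=C(CCCCC(S)CCS)Nc1ccc(Cl)cn1` has not yet been measured. The structural change is a single substitution, (chloro in place of hydrogen on an aromatic carbon), with chloro in place of hydrogen on an aromatic carbon of the six-membered aromatic ring. Among the compounds with values here, no measured pair shows this change on its own, so any expectation is indirect. Compound 2 carries the same chloro-bearing ring and gives 27.5%, although its chain differs from that of compound 4. A modest upward step from the inactive compound 3 is therefore expected, though the result could stay without a number. In this assay, the estimate for compound 4 is 18%, with an expected range of 3% to 35%.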

Compound 4, percent growth inhibition at one concentration: 21.9%
The estimate for compound 4 lay 3.9 percentage points below the measured number; measured number inside the range.
By their numbers in this assay, from the lowest: compounds 4, 1 and 2 (each within the scatter of the next).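

In this assay compound 3 gives "not active" (no number reported), whereas compound 4, with chloro on an aromatic carbon two atoms from the ring nitrogen, gives 21.9%, so this change turns a result without a number into a measurable one, though its size cannot be read. With the chloro-bearing ring kept, a ringless group in place of the five-membered non-aromatic ring gives a number 5.6 percentage points lower from compound 2 to compound 4 (within the scatter), so this read-out does not separate the open chain from the closed ring in this pair. Nothing measured here explains either result.

On these data alone, whether fluoro, bromo, methyl or methoxy on the same aromatic carbon would also give a measurable number remains open. So does whether a longer chain would leave the number within the scatter of these values.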